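Aryl Swap on the Oxadiazole Arm: Nitrophenyl Next

This account rests on a few compounds, and the source may have more. Where it says the series, first, only, none or still open, it means among the compounds named here.

Compound 1, `CC(C)(C)n1ncc(OCc2nnc(-c3cccs3)o2)c(Cl)c1=O`, in a functional assay on the whole organism for inhibition, with Mythimna separata as the target, with a stated time of 5 days; a lower number here means that less compound is needed, a higher number that more compound is needed for the effect: > 299000 nM, a limit of the assay rather than a number.
Compound 2, `CC(C)(C)n1ncc(OCc2nnc(-c3c(F)cccc3F)o2)c(Cl)c1=O`, in this assay: 45400 nM.
Compound 3, `CC(C)(C)n1ncc(OCc2nnc(-c3ccc(Cl)cc3F)o2)c(Cl)c1=O`, in this assay: 10400 nM.

Of the two numbers in hand, compound 3 holds the lowest, and the step of a 4.4-fold lower number from compound 2 to compound 3 (0.64 log units; beyond the scatter) sets it apart from its nearest neighbour. The step of an at least 28-fold lower number from compound 1 to compound 3 (1.45 log units; beyond the scatter) is larger still, though its starting point is only a limit, (the limit of > 299000 nM in this assay, at which 1 of the 3 values shown sits).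

Compound 4, `CC(C)(C)n1ncc(OCc2nnc(-c3ccc([N+](=O)[O-])cc3)o2)c(Cl)c1=O`, differs from compound 3 in one place: 4-nitrophenyl in place of 4-chloro-2-fluorophenyl on an aromatic carbon. The measured steps that touch this same carbon are an at least 6.5-fold lower number from compound 1 to compound 2 (0.81 log units; beyond the scatter), an at least 28-fold lower number from compound 1 to compound 3 (1.45 log units; beyond the scatter) and a 4.4-fold lower number from compound 2 to compound 3 (0.64 log units; beyond the scatter); each exchanges one aryl for another at this position, and each shifted the number well beyond the scatter. None of them involves a nitro group, so the direction for compound 4 rests on where compound 3 stands: it already has the lowest number, and every other aryl tried here gave a higher one. A modest rise, a 2.9-fold higher number from compound 3 to compound 4 (0.46 log units; beyond the scatter), is therefore expected, with wide uncertainty. Compound 4 is estimated at 30000 nM, expected to fall between 8000 nM and 150000 nM.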

Compound 4, half-maximal effective concentration: > 299000 nM
Compound 4 gave a limit, no number (the forecaster's own chance of this, stated with the estimate: 15%); middle value at least 9.9-fold (0.99 log units) from the limit.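

In this assay, the exchange to 4-nitrophenyl brought an at least 28-fold higher number from compound 3 to compound 4 (1.45 log units; beyond the scatter) and an at least 6.5-fold higher number from compound 2 to compound 4 (0.81 log units; beyond the scatter), so a phenyl ring on this carbon does not by itself secure a measurable number. Until now only the thiophen-2-yl compound had lacked one, which left open whether any phenyl ring would do; among these four compounds, the two with numbers, compound 2 and compound 3, both carry fluorine on the phenyl ring, while compound 1 and compound 4 carry no halogen at this position. The step between compound 1 and compound 4 cannot be read, and compound 4, like compound 1, stands at a limit rather than a number: the limit of > 299000 nM in this assay, at which 2 of the 4 values shown sit.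

The change from compound 3 to compound 4 removes the chlorine and the fluorine and adds the nitro group in a single exchange, so these compounds cannot separate the loss of the halogens from the arrival of the nitro group. Also open, from the compounds shown here alone, is how a plain phenyl, a 4-chlorophenyl without the fluorine or a 4-aminophenyl would behave on this carbon.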